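The source may hold more compounds than are shown below. What is called first, only, known or untested is meant among the compounds shown, and "the series" means these compounds.

Working notes on the diaryl ether amide series.

The parent, compound 1 `O=C(Nc1ccc(Oc2cc(C(F)(F)F)cc(C(F)(F)F)c2)cc1)c1ccccc1F`, carries an unsubstituted fluorinated benzamide and in an assay on HEK293 cells for inhibition of Toll-like receptor 8 (Homo sapiens), with a stated time of 16 h (on this read-out higher numbers stand for weaker inhibition and lower numbers for stronger inhibition), compound 1 gives 3000 nM. Compound 2 `O=C(Nc1ccc(Oc2cc(C(F)(F)F)cc(C(F)(F)F)c2)cc1)c1ccc(I)cc1F` adds an iodo group to that ring. For compound 2 this assay reports only a limit, > 50000 nM, and not a number. Among the measured compounds shown here, the one single-point step available, an at least 16-fold higher number from compound 1 to compound 2 (1.22 log units; beyond the scatter), is therefore a large loss, read against (the limit of > 50000 nM in this assay, at which 1 of the 3 values shown sits).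

Compound 3 `O=C(Nc1ccc(Oc2cc(C(F)(F)F)cc(C(F)(F)F)c2)cc1)c1c(F)cccc1C(F)(F)F` carries a trifluoromethyl on the benzamide ring. In this assay compound 3 stands at "not determined" (no result reported), so no number anchors it; where it sits between compound 1 and compound 2 is open.

Compound 4 `O=C(Nc1ccc(Oc2cc(C(F)(F)F)cc(C(F)(F)F)c2)cc1)c1c(F)cccc1OC(F)(F)F` differs from compound 3 by one change: trifluoromethoxy in place of trifluoromethyl on an aromatic carbon. For the measured compounds named here, no measured step touches a trifluoromethoxy for trifluoromethyl exchange, and the only step on record concerns iodo for hydrogen at a different position, so it gives no direction for this one. The expectation in this assay is a step of no set size or direction beyond the scatter, carried on the parent value of compound 1, 3000 nM, with wide bounds.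

Compound 4 is estimated at 6000 nM, expected to fall between 1500 nM and 30000 nM.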

Compound 4, half-maximal inhibitory concentration: > 50000 nM
Compound 4 gave a limit, no number; the forecaster's own chance of this, stated with the estimate: 35%; at least 8.3-fold (0.92 log units) between middle value and limit.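

In this assay the trifluoromethoxy group, ortho to a large group and meta to a fluoro group on the benzamide ring, brings an at least 16-fold higher number from compound 1 to compound 4 (1.22 log units; beyond the scatter), so the large loss first seen with the iodo group of compound 2 now also appears with a different group at a different place on that ring. On these data alone, compound 4 gives only a limit, > 50000 nM, and not a number, so the full size of the loss at this position is unknown. With both compound 2 and compound 4 carrying an added group on the ring of compound 1, the loss is no longer tied to iodo alone, though the reading remains capped: the limit of > 50000 nM in this assay, at which 2 of the 4 values shown sit.

The step between compound 2 and compound 4 cannot be read because both are limits, and with no result for compound 3, the exchange of trifluoromethyl for trifluoromethoxy has no measured size. As far as these compounds go, whether a methyl, a hydroxyl or an amine at this place would stay at the level of compound 1, 3000 nM, or also bring a large loss remains open.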